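Nitro for trifluoromethyl on the aryl of the shared core

This account rests on a few compounds, and the source may have more. Where it says the series, first, only, none or still open, it means among the compounds named here.

Compound 1 `O=c1c2c(sn1-c1ccc(C(F)(F)F)cc1)CCCC2` carries a trifluoromethyl on its aromatic ring. Among the measured compounds shown here, in a functional assay on the whole organism with Scenedesmus acutus as the target, read by spectrophotometry (on this read-out lower numbers stand for stronger inhibition and higher numbers for weaker inhibition), compound 1 gives 55000 nM, which is the highest of the two numbers measured so far. Compound 2 `CC(C)OC(=O)c1cc(-n2c(=O)c3c([s+]2[O-])CCCC3)ccc1Cl` is the other measured member. In this assay compound 2 gives 50100 nM, and the gap between compound 2 and compound 1 sits within the scatter, so the two values show no order between them.

Compound 3 `O=c1c2c(sn1-c1ccc([N+](=O)[O-])cc1)CCCC2` is not yet measured. It differs from compound 1 in one place: nitro in place of trifluoromethyl on an aromatic carbon. For the measured compounds named here, no pair of measured compounds covers this change, so nothing in the data fixes its size. Going by the values given here, with both measured values lying close together and no comparable step at hand, the expectation in this assay is for a step that does not exceed the scatter, in either direction. Compound 3 is therefore estimated at 45000 nM, with a range from 15000 nM to 135000 nM. The step that this estimate means is a 1.2-fold lower number from compound 1 to compound 3 (0.09 log units; within the scatter), and it is expected to fall within the scatter.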

Compound 3, half-maximal inhibitory concentration: 13200 nM
Compound 3: the middle estimate sits 3.4-fold (0.53 log units) above what was measured; the measured number lies below the stated range.
By their numbers in this assay, from the lowest: compound 3; then compounds 2 and 1 (each within the scatter of the next).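

In this assay the aromatic carbon para to a large group proves sensitive to what it carries: nitro in place of trifluoromethyl gives a 4.2-fold lower number from compound 1 to compound 3 (0.62 log units; beyond the scatter) and so moves the number by a modest but real amount. Among the compounds shown here, compound 1 and compound 2 differ in more than one place and offered no step of this kind, so this is the first change whose size can be read, and it shows that this position alone can shift the read-out beyond the scatter. Nothing available explains the step, which for now stands as an observation on a single pair.

One replacement at one position cannot show whether the shift belongs to nitro in particular or would also appear with a nitrile, an amine or a carboxylic acid on the same carbon, nor in which direction those groups would move the number. From the compounds shown here alone, it also remains open whether the same replacement would give a step of similar size on an aryl carrying other groups, such as the chlorine and isopropyl ester of compound 2.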